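The source may hold more compounds than are shown below. What is called first, only, known or untested is meant among the compounds shown, and "the series" means these compounds.

Measured so far:
Compound 1, `NC/C(=C\c1ccc(O)c(O)c1)C(=O)O`, gives 50.1%.
Compound 2, `O=C(O)/C(F)=C/c1ccc(O)c(O)c1`, gives -5.8%.
Compound 3, `N#C/C(=C\c1ccc(O)c(O)c1)C(=O)N1CCOCC1`, gives 40%.

These three values come from a functional assay on the whole organism (strain CD1) for inhibition, with Mus musculus as the target, with stated times of 15 min and 20 min, at a dose of 10 mg/kg by the subcutaneous route; a lower number here means less inhibition, a higher number more inhibition at the dose given (going by the name of the read-out). Compound 3 stands second of the three: compound 1 is higher, and compound 2 is far lower, the lowest number of the set. Going by the values given here, the only measured step, a number 55.9 percentage points lower from compound 1 to compound 2 (beyond the scatter), concerns the double-bonded chain carbon, where fluoro replaces aminomethyl, and it is large.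

Compound 4, `CC(C)CCOC(=O)/C(C#N)=C/c1ccc(O)c(O)c1`, differs from compound 3 in another place: isopentyloxy in place of morpholin-4-yl on a carbonyl carbon. A six-membered non-aromatic ring leaves, and a chain with no ring enters on the carbonyl carbon. Among the compounds with values here, no measured step touches the carbonyl carbon, so the step from compound 1 to compound 2 gives no direct guide to this change, and no direction can be read from the data. The expectation for compound 4 is therefore a value near that of compound 3, with a number 5 percentage points lower from compound 3 to compound 4 (within the scatter) as a step that may well stay within the scatter, and the estimate is 35%, ranging from 10% to 60%.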

Compound 4, a percentage reported as inhibition, in the whole organism at one dose (the size of the read-out at that dose, not a potency): 27.2%
Estimate against measurement, compound 4: 7.8 percentage points above, and the stated range covers the measured number.
By their numbers in this assay, from the lowest: compound 2; then compound 4; then compound 3; then compound 1.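

In this assay the carbonyl carbon now proves to be a place where a change shows: with isopentyloxy in place of morpholin-4-yl, the result is a number 12.8 percentage points lower from compound 3 to compound 4 (beyond the scatter) and the step is modest. The two groups match in heavy atoms, hydrogen-bond donors and hydrogen-bond acceptors, so those counts do not separate them, while a six-membered non-aromatic ring gives way to a chain with no ring and inhibition at this dose is still seen with that chain. No measurement at hand accounts for this step.

The compounds shown leave open whether the step follows the loss of the ring or the change of the atom joined to the carbonyl carbon. A diethylamino group would keep that nitrogen without a ring, and a cyclohexyloxy group would keep a ring with an oxygen in that place.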